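This account rests on a few compounds, and the source may have more. Where it says the series, first, only, none or still open, it means among the compounds named here.

Measured in a functional assay on C8166 cells (Homo sapiens) for cytotoxicity, read by MTT assay; a lower number here means that less compound is tolerated, a higher number that more compound is tolerated:
- Compound 1 `Cc1cccc(C(=O)Nc2cc(Cl)ccc2OCC(=O)Nc2ccc(S(N)(=O)=O)cc2C)c1`: 52900 nM
- Compound 2 `Cc1ccc(C(=O)Nc2cc(Cl)ccc2OCC(=O)Nc2ccc(S(N)(=O)=O)cc2C)cc1`: 54200 nM

Compound 2 stands level with compound 1, as the two numbers lie within the scatter of each other. The next molecule, compound 3 `Cc1cc(S(N)(=O)=O)ccc1NC(=O)COc1ccc(Cl)cc1NC(=O)c1cccc(Cl)c1`, keeps the shared core and changes a single group, 3-chlorophenyl in place of 4-methylphenyl on a carbonyl carbon.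

Going by the values given here, only one measured step bears on this change. It exchanged 3-methylphenyl for 4-methylphenyl on the same carbonyl carbon, and it gave a 1.0-fold higher number from compound 1 to compound 2 (0.01 log units; within the scatter). That step shows that this assay did not separate those two groups, but it is thin evidence. Among the compounds with values here, no measured pair exchanges a methyl group for a chlorine, so the data cannot say directly what the new group will do.

The safest expectation is therefore no change beyond the scatter, with the number staying near that of compound 2 at 54200 nM. The expected change is a 1.1-fold lower number from compound 2 to compound 3 (0.04 log units; within the scatter). For compound 3 the estimated value is 50000 nM, with an expected range from 26000 nM to 95000 nM.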

Compound 3, half-maximal cytotoxic concentration: 59700 nM
Estimate against measurement, compound 3: 1.2-fold (0.08 log units) below, within the range that was stated.
By their numbers in this assay, from the lowest: compounds 1, 2 and 3 (each within the scatter of the next).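

Swapping 4-methylphenyl for 3-chlorophenyl on the carbonyl carbon gives a 1.1-fold higher number from compound 2 to compound 3 (0.04 log units; within the scatter) in this assay, so this assay does not separate these two groups, which differ both in the substituent and in where the name places it. Going by these compounds alone, the more direct comparison is the exchange of chloro for methyl on an aromatic carbon, with the name's position 3 kept, and it gives a 1.1-fold higher number from compound 1 to compound 3 (0.05 log units; within the scatter) as the first measured exchange of these two substituents. All three compounds therefore lie within the scatter of one another, and no separate measurement offers an explanation for this result.

From the compounds shown here alone, these compounds cover only a methyl or chloro group on the phenyl ring, so it remains open whether 4-chlorophenyl would also stay within the scatter of them. Going by these compounds, it is equally open whether an amine, a carboxylic acid or a longer chain on that ring, or a different ring on the carbonyl carbon, would move the number in this assay beyond the scatter.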